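Cutting the sulfonyl chain back to ethylsulfonyl

The compounds below may be only part of what the source reports. "The series", "measured", "known", "first", "only" and "open" are said of these compounds alone.

In an ADME assay for permeability, using PAMPA (on this read-out higher numbers stand for higher permeability and lower numbers for lower permeability), compound 1 (`NC(=O)c1cc(-c2ccccc2)cc2c(C3CCN(S(=O)(=O)CCCN4CCCCCC4)CC3)c[nH]c12`) reads 290 nm/s and compound 2 (`NC(=O)c1cc(-c2ccccc2)cc2c(C3CCN(S(=O)(=O)CCCN4CCCCC4)CC3)c[nH]c12`) reads 240 nm/s while compound 3 (`NC(=O)c1cc(-c2ccccc2)cc2c(C3CCN(S(=O)(=O)CCCN4CCCC4)CC3)c[nH]c12`) reads 160 nm/s on the same scale. Compound 3 stands within the scatter of both other compounds.

Next comes compound 4 (`CCS(=O)(=O)N1CCC(c2c[nH]c3c(C(N)=O)cc(-c4ccccc4)cc23)CC1`) on the shared core. The change is hydrogen in place of (pyrrolidin-1-yl)methyl on a saturated chain carbon, two bonds along the chain from a sulfonyl sulfur and, cut one bond further out, it reads (3-(pyrrolidin-1-yl)propyl)sulfonyl to ethylsulfonyl.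

For the measured compounds named here, three measured steps bear on this only loosely: a 1.2-fold lower number from compound 1 to compound 2 (0.08 log units; within the scatter) and a 1.5-fold lower number from compound 2 to compound 3 (0.18 log units; within the scatter) and a 1.8-fold lower number from compound 1 to compound 3 (0.26 log units; within the scatter) all lie within the scatter. Each exchanges azepan-1-yl, piperidin-1-yl or pyrrolidin-1-yl for another of these groups. Going by the values given here, none removes the group altogether, so the data hold no direct precedent for this change. On the structural change alone, a rise beyond the scatter is tentatively expected. The expected step is a 2.5-fold higher number from compound 3 to compound 4 (0.40 log units; beyond the scatter) in this assay with wide uncertainty. For compound 4 the estimated value is 400 nm/s within an expected range of 130 nm/s to 1000 nm/s as a working figure.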

Compound 4, apparent permeability: 250 nm/s
Estimate against measurement, compound 4: 1.6-fold (0.20 log units) above, within the range that was stated.
By their numbers in this assay, from the lowest: compounds 3, 2, 4 and 1 (each within the scatter of the next).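

In this assay the loss of the (pyrrolidin-1-yl)methyl group, a removal of the ring and not an exchange of one ring for another, gives a 1.6-fold higher number from compound 3 to compound 4 (0.19 log units; within the scatter) and the matching removals give a 1.0-fold higher number from compound 2 to compound 4 (0.02 log units; within the scatter) and a 1.2-fold lower number from compound 1 to compound 4 (0.06 log units; within the scatter) and all three steps lie within the scatter. On the saturated chain carbon two bonds along the chain from a sulfonyl sulfur, hydrogen therefore reads the same on this scale as the azepane, piperidine and pyrrolidine rings carried further out, so the ring is not needed to hold the read-out among these four compounds. No supporting measurement bears on why these compounds read alike.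

As far as these compounds go, whether another kind of group on the same chain, such as a carboxylic acid, a hydroxyl or an open-chain dimethylamino group, would step beyond the scatter stays open. So does whether methylsulfonyl or a longer unbranched alkyl chain would read as ethylsulfonyl does in this assay on the shared core.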